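Tolerance in Liver Cells: From Compound 1 to Compound 4

The source may report more compounds than this note shows. Statements on the series, on what has been measured and on what is new or still open speak of the compounds shown alone.

Compound 1 `O=[N+]([O-])c1c(CS(=O)(=O)c2ccccc2)nc2c(-c3ccc(Cl)cc3)cc(Cl)cn12` gives > 3900 nM in an ADME assay on HepG2 cells (Homo sapiens) for cytotoxicity, read by MTT assay, with a stated time of 72 h (a higher number here means that more compound is tolerated, a lower number that less compound is tolerated), which is a limit of the assay.
Compound 2 `O=Cc1ccc(-c2cc(Cl)cn3c([N+](=O)[O-])c(CS(=O)(=O)c4ccccc4)nc23)cc1` gives > 31200 nM in this assay, again a limit.
Compound 3 `O=[N+]([O-])c1c(CS(=O)(=O)c2ccccc2)nc2c(-c3cccc(F)c3)cc(Cl)cn12` gives > 12500 nM in this assay, also a limit.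

Compound 1 thus stands only at a limit, and the two other values are limits as well (the limit of > 3900 nM in this assay, at which 1 of the 3 values shown sits). Compound 4 `O=[N+]([O-])c1c(CS(=O)(=O)c2ccccc2)nc2c(-c3ccccc3F)cc(Cl)cn12` differs from compound 1 by 2-fluorophenyl in place of 4-chlorophenyl on an aromatic carbon. Among the compounds with values here, the steps that bear on this change, a step that the two limits leave unreadable from compound 1 to compound 2, a step that the two limits leave unreadable from compound 1 to compound 3 and a step that the two limits leave unreadable from compound 2 to compound 3, all run between limits, so their size cannot be read; the limit of > 12500 nM in this assay, at which 1 of the 3 values shown sits, and the limit of > 31200 nM in this assay, at which 1 of the 3 values shown sits, show only where each value sits. No direction beyond the scatter can be drawn, and compound 4 is expected to be tolerated at a similar level, the expected step being a step that the limit leaves unreadable from compound 1 to compound 4. Compound 4 is estimated at 20000 nM in this assay, within 5000 nM to 100000 nM.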

Compound 4, half-maximal cytotoxic concentration: > 3900 nM
Compound 4: no number, only a limit (the forecaster's own chance of this, stated with the estimate: 80%); the middle value lies beyond the limit too.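

Compound 4 gives only a limit in this assay, as do compound 1, compound 2 and compound 3, so none of its steps to them can be read. The compounds shown leave open whether swapping these aryl groups changes tolerance at all.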